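Chloropyridinyl in Place of Chlorophenyl on the Amide Nitrogen

The source may hold more compounds than are shown below. What is called first, only, known or untested is meant among the compounds shown, and "the series" means these compounds.

Of the compounds shown here, two carry numbers so far. Compound 1 `Cc1noc(C)c1-c1cnc(N)c(Oc2ccc(C(=O)Nc3ccc(Cl)cc3)cc2)n1` in a functional assay on HepG2 cells (Homo sapiens) for inhibition, read by MTT assay, with a stated time of 72 h (on this read-out higher numbers stand for weaker inhibition and lower numbers for stronger inhibition), gives 14400 nM. Among the compounds with values here, compound 2 `Cc1noc(C)c1-c1cnc(N)c(Oc2ccc(C(=O)Nc3cccc(Cl)c3)cc2)n1` in this assay gives 7300 nM, the lowest of the two numbers; the only step known, a 2.0-fold lower number from compound 1 to compound 2 (0.30 log units; within the scatter), does not separate the two compounds on this read-out. Compound 3 `Cc1noc(C)c1-c1cnc(N)c(Oc2ccc(C(=O)Nc3cccc(Cl)n3)cc2)n1` has not yet been measured. It differs from compound 2 in one place: 6-chloropyridin-2-yl in place of 3-chlorophenyl on an amide-type nitrogen. Within the data shown here, no measured step covers the exchange of a six-membered aromatic ring of carbon only for one with a hetero atom; the single step in hand, from compound 1 to compound 2, concerned only the chlorine and stayed within the scatter. With nothing in the series pointing in either direction, the step is expected to be small, and no change at the digits printed from compound 2 to compound 3 (within the scatter) is the expected change, none beyond the scatter. Compound 3 is therefore estimated at 7300 nM in this assay, with an expected range from 2500 nM to 22000 nM.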

Compound 3, half-maximal inhibitory concentration: 35700 nM
The estimate for compound 3 lay 4.9-fold (0.69 log units) below the measured number, outside the stated range (above it).
By their numbers in this assay, from the lowest: compounds 2 and 1 (each within the scatter of the next); then compound 3.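

In this assay, the exchange of the carbon-only ring on the amide-type nitrogen for a ring with one hetero atom gives a change beyond the scatter, a 4.9-fold higher number from compound 2 to compound 3 (0.69 log units; beyond the scatter), whereas the earlier change among the chlorophenyl groups, a 2.0-fold lower number from compound 1 to compound 2 (0.30 log units; within the scatter), stayed within it. The direction holds against the other chlorophenyl amide as well, a 2.5-fold higher number from compound 1 to compound 3 (0.39 log units; beyond the scatter), so on this read-out the 6-chloropyridin-2-yl amide inhibits more weakly than either chlorophenyl amide, and this position proves sensitive to what the ring is made of, not only to where the chlorine sits. No measurement is at hand that would account for this loss of inhibition.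

The compounds shown leave open whether the change belongs to the ring nitrogen alone or depends on the chlorine that accompanies it, a question that a plain phenyl paired with a plain pyridinyl ring, or a methyl or methoxy group in place of the chlorine, would bear on. They also leave open how a ring with two nitrogens, such as a pyrimidinyl group, would read at this position.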